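This account rests on a few compounds, and the source may have more. Where it says the series, first, only, none or still open, it means among the compounds named here.

Measured in an assay (Rattus norvegicus) for inhibition of Fatty-acid amide hydrolase 1 (Homo sapiens); on this read-out higher numbers stand for weaker inhibition and lower numbers for stronger inhibition:
compound 1 `COc1ccc(-c2cnc(C(=O)CCCCCCc3ccccc3)o2)cc1` gives 100 nM
compound 2 `O=C(CCCCCCc1ccccc1)c1ncc(-c2ccc(C(=O)C(F)(F)F)cc2)o1` gives 65 nM
compound 3 `O=C(CCCCCCc1ccccc1)c1ncc(-c2cc(C(F)(F)F)ccn2)o1` gives 3.5 nM

Compound 1 stands at the highest number of the three in this assay; compound 2 sits within the scatter of it, while compound 3 lies well beyond. Compound 4 `O=C(CCCCCCc1ccccc1)c1ncc(-c2ncccn2)o1` differs from compound 1 as follows: pyrimidin-2-yl in place of 4-methoxyphenyl on an aromatic carbon. For the measured compounds named here, the only single-point step on record, a 1.5-fold lower number from compound 1 to compound 2 (0.19 log units; within the scatter), changes a substituent on the six-membered ring and is within the scatter, so it says little about exchanging the ring itself. The values of compound 1 and compound 3 show that a six-membered ring with hetero atoms in this position can go with a far lower number, though compound 3 also carries trifluoromethyl. For compound 4 a lower number than compound 1 is therefore expected, roughly a 6.7-fold lower number from compound 1 to compound 4 (0.82 log units; beyond the scatter), though less than compound 3 reaches. The estimate for compound 4 is 15 nM, with a range from 4 nM to 60 nM.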

Compound 4, inhibition constant: 5.3 nM
The estimate for compound 4 lay 2.8-fold (0.45 log units) above the measured number; the range from low to high includes it.
By their numbers in this assay, from the lowest: compounds 3 and 4 (each within the scatter of the next); then compounds 2 and 1 (each within the scatter of the next).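

The step of a 19-fold lower number from compound 1 to compound 4 (1.28 log units; beyond the scatter) in this assay shows that pyrimidin-2-yl on this aromatic carbon, next to the ring oxygen, goes with a far lower number than 4-methoxyphenyl. Compound 4 reaches its value without the trifluoromethyl carried by compound 3, so that group is not required for a low number here. No measurement on hand explains the step.

The change removes methoxy and exchanges the ring together, so the two contributions remain unseparated. Also open, as far as these compounds go, is how an amine or a carboxylic acid on the pyrimidin-2-yl ring would shift the number.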